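The source may hold more compounds than are shown below. What is called first, only, known or untested is meant among the compounds shown, and "the series" means these compounds.

Measured so far in a functional assay on HT-29 cells (Homo sapiens) for antiproliferative activity, read by MTT assay, with a stated time of 72 h; on this read-out higher numbers stand for weaker inhibition and lower numbers for stronger inhibition:

- compound 1 `CCCCCn1ccnc1-c1cc(OC)c(OC)c(OC)c1`: 60100 nM
- compound 2 `COc1cc(-c2nccn2S(=O)(=O)c2ccccc2)cc(OC)c1OC`: > 100000 nM (a limit of the assay, not a number)
- compound 3 `COc1cc(-c2nccn2-c2ccc3sccc3c2)cc(OC)c1OC`: 1500 nM

Of the two actual numbers, compound 1 holds the higher at 60100 nM and compound 3 the lower at 1500 nM, a gap beyond the scatter. Compound 2 is recorded only as a limit.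

Compound 4 `COc1ccc(-n2ccnc2-c2cc(OC)c(OC)c(OC)c2)cc1` is still unmeasured. Compared with compound 1, it carries 4-methoxyphenyl in place of pentyl on an aromatic nitrogen.

Going by the values given here, no step between measured compounds isolates this change, so the expectation rests on a single comparison. Among the compounds with values here, compound 3, at 1500 nM, is the only measured compound with an aromatic ring directly on that nitrogen. Expected in this assay is a 75-fold lower number from compound 1 to compound 4 (1.88 log units; beyond the scatter) toward stronger inhibition, well beyond the scatter. For compound 4 the estimated value is 800 nM, with an expected range of 60 nM to 10000 nM, kept wide on such thin support.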

Compound 4, half-maximal inhibitory concentration: 13100 nM
Compound 4: the middle estimate sits 16-fold (1.21 log units) below what was measured, and the stated range ends below it.
By their numbers in this assay, from the lowest: compound 3; then compound 4; then compound 1. At a limit, above all of these: compound 2.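

In this assay, going by these compounds alone, the first readable step at this nitrogen is a 4.6-fold lower number from compound 1 to compound 4 (0.66 log units; beyond the scatter) and shows that an aromatic ring can replace the open chain with a modest gain. A six-membered aromatic ring carrying methoxy on this nitrogen does not by itself bring the number down to that of compound 3 at 1500 nM in the same assay. Nothing at hand speaks to the cause of the step from pentyl to 4-methoxyphenyl.

Open, on these data alone, is whether the gain belongs to the aromatic ring itself or to its methoxy group, which unsubstituted phenyl on the same nitrogen would separate. Also open, as far as these compounds go, is how an amine or a carboxylic acid on that ring, or a longer chain in place of pentyl, would move the number.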